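The source may report more compounds than this note shows. Statements on the series, on what has been measured and on what is new or still open speak of the compounds shown alone.

Compound 1 `O=C(CSc1nc(Nc2ccccc2)c2ccccc2n1)Nc1ccccc1F` gives 12400 nM in a functional assay on PC-3 cells (Homo sapiens) for inhibition, read by MTT assay, with a stated time of 72 h; a higher number here means a weaker inhibitor, a lower number a stronger inhibitor. Compound 2 `O=C(CSc1nc(Nc2ccccc2)c2ccccc2n1)Nc1ccccc1Br` gives 19800 nM, and compound 3 `O=C(CSc1nc(Nc2ccccc2)c2ccccc2n1)Nc1cccc(F)c1` gives 15600 nM. The number for compound 1 is the lowest of the three, yet the steps of a 1.6-fold higher number from compound 1 to compound 2 (0.20 log units; within the scatter) and a 1.3-fold higher number from compound 1 to compound 3 (0.10 log units; within the scatter) both stay within the scatter, so the three compounds cannot be told apart on these numbers. Compound 4 `CCc1cccc(NC(=O)CSc2nc(Nc3ccccc3)c3ccccc3n2)c1` differs from compound 1 by 3-ethylphenyl in place of 2-fluorophenyl on an amide-type nitrogen. The two measured steps that change the group on the amide-type nitrogen bear on this change, and each was within the scatter; a step of similar size, in no particular direction, is therefore expected from compound 1 to compound 4, namely a 1.1-fold higher number from compound 1 to compound 4 (0.05 log units; within the scatter). Compound 4 is thus estimated at 14000 nM, with a range from 5000 nM to 40000 nM.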

Compound 4, half-maximal inhibitory concentration: 11000 nM
For compound 4 the middle estimate is 1.3-fold (0.10 log units) above the measured one; low and high end bracket the measured number.
By their numbers in this assay, from the lowest: compounds 4, 1, 3 and 2 (each within the scatter of the next).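

In this assay the position on the amide-type nitrogen accepts 3-ethylphenyl: a 1.1-fold lower number from compound 1 to compound 4 (0.05 log units; within the scatter) and a 1.4-fold lower number from compound 3 to compound 4 (0.15 log units; within the scatter) and a 1.8-fold lower number from compound 2 to compound 4 (0.26 log units; within the scatter) all stay within the scatter. The earlier compounds shown here carried only halogens on this phenyl ring, whereas ethyl, a carbon-only group, now gives numbers that cannot be told apart from theirs. Nothing measured here offers an explanation for this flat result. Going by these compounds, whether an amine, a carboxylic acid or a longer chain on this ring would move the number beyond the scatter stays open.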